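The source may report more compounds than this note shows. Statements on the series, on what has been measured and on what is new or still open speak of the compounds shown alone.

In a functional assay on MDA-MB-231 cells (Homo sapiens) for antiproliferative activity, read by MTT assay, with a stated time of 48 h (a lower number here means a stronger inhibitor, a higher number a weaker inhibitor), compound 1 `CN1C(=O)C(O)(Cc2nnn[nH]2)c2ccccc21` gives > 100000 nM as a limit and not a number. Compound 2 `CCN1C(=O)C(O)(Cc2nnn[nH]2)c2ccccc21` gives > 100000 nM as a limit too. Compound 3 `CN1C(=O)C(O)(Cc2nnn[nH]2)c2cc(F)ccc21` gives > 100000 nM as a limit as well, so it offers no number to start from.

Compound 4 `O=C1N(Cc2ccc(Br)cc2)c2ccc(F)cc2C1(O)Cc1nnn[nH]1` is not yet measured and differs from compound 3 by 4-bromophenyl in place of hydrogen on a saturated chain carbon bound to an amide-type nitrogen in a ring in one place. That change can also be read as methyl to 4-bromobenzyl. Within the data shown here, two measured steps bear on it: a step that the two limits leave unreadable from compound 1 to compound 2 at the same place and a step that the two limits leave unreadable from compound 1 to compound 3 on an aromatic carbon. Neither has a size that can be carried over. The evidence amounts to the limit of > 100000 nM in this assay, at which 3 of the 3 values shown sit, and gives no direction.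

A move toward a lower number in this assay is expected on the size of the entering group alone, and a further limit remains quite possible. The expected step is an at least 1.6-fold lower number from compound 3 to compound 4 (0.22 log units; that floor lies within the scatter) and it is a loose one. For compound 4 the estimated value is 60000 nM with an expected range of 15000 nM to 200000 nM in this read-out.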

Compound 4, half-maximal inhibitory concentration: > 100000 nM
Compound 4: a limit, no number; the forecaster's own chance of this, stated with the estimate: 50%; at least 1.6-fold (0.22 log units) between middle value and limit.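

In this assay, among these compounds, compound 4 gives > 100000 nM, a limit and not a number, so no step from compound 3 to compound 4 can be read. The compounds shown leave open whether any change on the shared core yields a measurable value, and how large its effect would be.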